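Replacing the Methylphenyl Ether with a Chlorophenyl Ether

The source may hold more compounds than are shown below. What is called first, only, known or untested is meant among the compounds shown, and "the series" means these compounds.

Compound 1, `Cc1ccccc1Oc1ccc(N2C[C@@H](C(F)(F)F)C[C@H]2CC(=O)O)cc1`, in a functional assay on cells for agonist activity at Free fatty acid receptor 1 (Mus musculus), read by FLIPR and calcium flux, with a stated time of 100 s (on this read-out lower numbers stand for an effect already at smaller amounts and higher numbers for an effect only at larger amounts of compound), gives 330 nM.
Compound 2, `Cc1ccccc1Oc1ccc(N2CCC[C@H]2CC(=O)O)cc1`, gives 5600 nM.
Compound 3, `CCOc1ccccc1Oc1ccc(N2CCC[C@H]2CC(=O)O)cc1`, gives > 33000 nM, which is a limit of the assay.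

Among the two numbers shown, compound 2 stands highest; the step of a 17-fold higher number from compound 1 to compound 2 (1.23 log units; beyond the scatter) separates it from compound 1. The step of an at least 5.8-fold higher number from compound 2 to compound 3 (0.77 log units; beyond the scatter) moved further upward. Compound 3 sits at the limit of > 33000 nM in this assay, at which 1 of the 3 values shown sits. Compound 4, `O=C(O)C[C@@H]1CCCN1c1ccc(Oc2ccc(Cl)cc2)cc1`, differs from compound 2 by 4-chlorophenyl in place of 2-methylphenyl on an oxygen on an aromatic ring. Of the measured steps, only the change on the same phenyl ether, from compound 2 to compound 3, bears on this change; it was at least modest and upward. Compound 4 is therefore expected to show a modest upward step, a 1.8-fold higher number from compound 2 to compound 4 (0.25 log units; within the scatter), and is estimated at 10000 nM, with a range from 3000 nM to 33000 nM.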

Compound 4, half-maximal effective concentration: > 33000 nM
Compound 4 was reported as a limit; the forecaster's own chance of this, stated with the estimate: 25%; middle value at least 3.3-fold (0.51 log units) away from the limit.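

On this oxygen a second replacement now also raises the number, this time a change of the whole aryl group rather than of one group on it: an at least 5.8-fold higher number from compound 2 to compound 4 (0.77 log units; beyond the scatter). From the compounds shown here alone, compound 4 gives > 33000 nM, which is a limit and not a number, so the true size of the step stays unknown. Two of the compounds now end at that ceiling in this assay: the limit of > 33000 nM in this assay, at which 2 of the 4 values shown sit.

Going by these compounds, it remains open whether a plain phenyl or a 4-fluorophenyl on this oxygen would keep a measurable value. Also open, on these data alone, is whether the trifluoromethyl of compound 1 would bring such ethers back into range.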